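This account rests on a few compounds, and the source may have more. Where it says the series, first, only, none or still open, it means among the compounds named here.

Measured so far:
compound 1, `O=[N+]([O-])c1ccc(-c2nc3cccnc3o2)cc1`: 5%
compound 2, `Fc1ccc(-c2nc3ncccc3o2)c(F)c1`: 23%

Notes on the series. In a functional assay on the whole organism for inhibition, with Rattus norvegicus as the target, at a dose of 30 mg/kg (on this read-out higher numbers stand for more inhibition at the one dose given (going by the name of the read-out) and lower numbers for less inhibition), compound 1 gives 5%, the lowest of the two numbers available. The nearest number belongs to compound 2, which in this assay gives 23%; that gap lies beyond the usual scatter of the measurement, so compound 1 sits clearly below compound 2. Within the data shown here, no pair of measured compounds differs in a single place, so no single-change step has been measured yet.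

The next compound is compound 3, `N#Cc1ccc(-c2nc3cccnc3o2)cc1`, not yet measured in this assay. It differs from compound 1 by one change: cyano in place of nitro on an aromatic carbon

Among the measured compounds shown here, with no measured step of this kind at hand, the expectation for the step from compound 1 to compound 3 is modest: a small rise in inhibition at most, and possibly nothing beyond the scatter, which is what a number 5 percentage points higher from compound 1 to compound 3 (within the scatter) is meant to express. Compound 3 is therefore expected to give about 10% in this assay, within a range from 0% to 30%.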

Compound 3, a percentage reported as inhibition, in the whole organism at one dose (the size of the read-out at that dose, not a potency): 17%
For compound 3 the middle estimate is 7 percentage points below the measured one; the measured number falls inside the stated range.
By their numbers in this assay, from the lowest: compound 1; then compounds 3 and 2 (each within the scatter of the next).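

Cyano in place of nitro on an aromatic carbon, para to a group of 9 heavy atoms, gives the first single-change step of the series in this assay, with a number 12 percentage points higher from compound 1 to compound 3 (beyond the scatter) as the result. This position therefore responds to a change of substituent while the core of compound 1 stays the same, and the exchange of nitro for cyano moves the read-out by more than the usual scatter. The structures count one heavy atom and one hydrogen-bond acceptor fewer in the group that enters, but no measured property accompanies this step, and the data do not show what lies behind it.

An amine, a carboxylic acid or a methoxy group at this same place on the core of compound 1 would show whether the read-out keeps moving with the substituent or whether this pair is an isolated case. A single pair at a single dose also leaves open whether the same exchange gives a similar step on another core, and it says nothing about potency.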